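A few compounds are considered here, and "the series" means these few. Any claim that something is new, unique, unknown or untested is made for them only; others in the source may bear on it.

Three compounds on the shared core have readings in a functional assay on OVCAR-3 cells (Homo sapiens) for antiproliferative activity, read by MTT assay, with a stated time of 24 h; a higher number here means a weaker inhibitor, a lower number a stronger inhibitor. Compound 1 `O=C(NNc1ccccc1Cl)c1ccc(NS(=O)(=O)c2cnc(O)nc2O)cc1` gives 7230 nM and compound 3 `CCCCOc1ccc(C(=O)NNC(=O)c2ccc(NS(=O)(=O)c3cnc(O)nc3O)cc2)cc1` gives 12800 nM, two numbers within the scatter of each other. Compound 2 `Cc1ccccc1NNC(=O)c1ccccc1NS(=O)(=O)c1cnc(O)nc1O` has only a limit, > 20000 nM. Compound 3 therefore holds the highest actual number in the series, but that position does not separate it from compound 1.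

Compound 4 `O=C(NNC(=O)c1ccccc1F)c1ccc(NS(=O)(=O)c2cnc(O)nc2O)cc1` is still unmeasured. It is related to compound 3 by 2-fluorophenyl in place of 4-butoxyphenyl on a carbonyl carbon, with 2-fluorophenyl in place of 4-butoxyphenyl on a carbonyl carbon. Among the measured compounds shown here, the series offers no measured step for this change, so the expectation in this assay is anchored on compound 3 at 12800 nM. No shift beyond the scatter is expected, in either direction. The estimated step is a 1.2-fold lower number from compound 3 to compound 4 (0.07 log units; within the scatter). Compound 4 is estimated at 11000 nM, with an expected range of 4500 nM to 25000 nM.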

Compound 4, half-maximal inhibitory concentration: 16000 nM
Compound 4: the middle estimate sits 1.5-fold (0.16 log units) below what was measured, within the range that was stated.
By their numbers in this assay, from the lowest: compounds 1, 3 and 4 (each within the scatter of the next, the first and the last beyond it). At a limit, above all of these: compound 2.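

Swapping 4-butoxyphenyl for 2-fluorophenyl on a carbonyl carbon gives the first measured step at this place in this assay: a 1.3-fold higher number from compound 3 to compound 4 (0.10 log units; within the scatter). Within the scatter, this step shows that the two aryl groups are not told apart here, even though the butoxy chain and its oxygen leave and a fluorine enters. Among the compounds shown here, the second step, with (2-fluorophenyl)carbonyl in place of 2-chlorophenyl on an amine nitrogen, gives a 2.2-fold higher number from compound 1 to compound 4 (0.34 log units; beyond the scatter), the only step here beyond the scatter, and a modest one.

As far as these compounds go, whether an amine, a carboxylic acid or a chain longer than butoxy on this aromatic ring would move the reading beyond the scatter remains open. Compound 2 remains a limit of the assay, not a number: the limit of > 20000 nM in this assay, at which 1 of the 4 values shown sits.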